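The source may hold more compounds than are shown below. What is called first, only, known or untested is meant among the compounds shown, and "the series" means these compounds.

Measured so far in a physicochemical assay for lipophilicity, measured as octanol-water partition; a lower number here means a more polar compound, a higher number a more lipophilic compound
- compound 1 `C#CCc1c(Cl)cc(N/C=N/OCCCC)cc1Cl`, 4.4
- compound 2 `C#CCc1c(Cl)cc(N/C=N/OCC#N)cc1Cl`, 3
- compound 3 `C#CCc1c(Cl)cc(N/C=N/OC/C=C\Cl)cc1Cl`, 3.9

Compound 3 holds the middle place of the three numbers. It lies closer to the top of the set, with a number 0.50 log units lower from compound 1 to compound 3 (beyond the scatter), and further from the bottom, with a number 0.90 log units higher from compound 2 to compound 3 (beyond the scatter). Both gaps are beyond the scatter.

The next compound is compound 4 `C#CCc1c(Cl)cc(N/C=N/OC/C=C/Cl)cc1Cl`. The change is the two compounds have the same atoms and bonds and differ only in configuration as drawn: 1 of 2 stereo elements differ; a double bond is drawn Z in compound 3 and E in compound 4. The two compounds have the same atoms and bonds, and a double bond is drawn Z in compound 3 and E in compound 4.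

Among the measured compounds shown here, no measured step is a change of configuration alone, so the data give no direct precedent. The nearest evidence comes from steps that replace the whole group on the saturated chain carbon bound to an oxygen. These are the large a number 1.40 log units lower from compound 1 to compound 2 (beyond the scatter) and the two modest steps already given. Each of them alters atoms and bonds, which the present change does not, so they offer only an outer frame for its size. The expectation therefore stays anchored on compound 3 at 3.9, with no preferred direction. The expected result is no change at the digits printed from compound 3 to compound 4 (within the scatter), which would be no step beyond the scatter. For compound 4 the estimated value is 3.9, with an expected range of 3.6 to 4.2.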

Compound 4, partition coefficient: 3.9
Compound 4: middle estimate and measured number agree at the digits printed, within the range that was stated.
By their numbers in this assay, from the lowest: compound 2; then compounds 3 and 4 (each within the scatter of the next); then compound 1.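

In this assay, the series now has a step of configuration alone, and it reads no change at the digits printed from compound 3 to compound 4 (within the scatter); this comparison isolates the drawing of the double bond in the 2-chloroethenyl group because nothing else differs: the fact that compounds 3 and 4 differ only in the configuration as drawn

Replacing the whole group gives a number 0.90 log units higher from compound 2 to compound 4 (beyond the scatter) and a number 0.50 log units lower from compound 1 to compound 4 (beyond the scatter), the same sizes as the steps for the Z compound, a number 0.90 log units higher from compound 2 to compound 3 (beyond the scatter) and a number 0.50 log units lower from compound 1 to compound 3 (beyond the scatter). Across these four compounds, the numbers therefore separate with the identity of the group on the saturated chain carbon bound to an oxygen, while the Z and E drawings of this double bond do not separate them, and no compound shown goes against this.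

From the compounds shown here alone, the result covers one pair, so it remains open whether a Z and E pair would also read alike with the double bond set in a longer chain or with bromo in place of chloro on the ethenyl group. The series also leaves open how an amine or a carboxylic acid on this carbon would read in this assay, and whether the other double bond, drawn the same way in all four compounds, would matter if drawn the opposite way.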